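Oxanylmethyl amide: expected permeability from two measured analogues

A few compounds are considered here, and "the series" means these few. Any claim that something is new, unique, unknown or untested is made for them only; others in the source may bear on it.

Going by the values given here, compound 2 `O=C(NCc1cc[nH]n1)c1ccc([C@H]2[C@@H](F)[C@@H](F)C[C@@H](F)[C@H]2F)cc1` gives 2.1 10^-6 cm/s in an ADME assay on MDCK-MDR1 cells (Canis lupus familiaris) for permeability, in the apical to basolateral direction, with a stated time of 180 min (on this read-out lower numbers stand for lower permeability and higher numbers for higher permeability), the lowest of the two numbers measured so far. Compound 1 `CN(Cc1cccnc1)C(=O)c1ccc([C@H]2[C@@H](F)[C@@H](F)C[C@@H](F)[C@H]2F)cc1` gives 16.3 10^-6 cm/s in this assay, and the step of a 7.8-fold lower number from compound 1 to compound 2 (0.89 log units; beyond the scatter) lies beyond the scatter. Compound 3 `O=C(NCC1CCOCC1)c1ccc([C@H]2[C@@H](F)[C@@H](F)C[C@@H](F)[C@H]2F)cc1` differs from compound 2 by oxan-4-yl in place of 1H-pyrazol-3-yl on a saturated chain carbon bound to an amide-type nitrogen. Among the compounds with values here, only the step from compound 1 to compound 2 bears on this change, and it was modest. Since the leaving group carries 1 hydrogen-bond donor and the entering group 0, a rise is expected for compound 3, of about a 3.3-fold higher number from compound 2 to compound 3 (0.52 log units; beyond the scatter). Compound 3 is therefore estimated at 7 10^-6 cm/s, with a range from 3 10^-6 cm/s to 16 10^-6 cm/s.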

Compound 3, apparent permeability: 20.3 10^-6 cm/s
Beside the measured number, compound 3's estimate is 2.9-fold (0.46 log units) below it; measured number above the stated range.
By their numbers in this assay, from the lowest: compound 2; then compounds 1 and 3 (each within the scatter of the next).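

In this assay, the group on the saturated chain carbon bound to an amide-type nitrogen matters: oxan-4-yl in place of 1H-pyrazol-3-yl gives a 9.7-fold higher number from compound 2 to compound 3 (0.99 log units; beyond the scatter). The change from methyl((pyridin-3-yl)methyl)amino to ((oxan-4-yl)methyl)amino gives a 1.2-fold higher number from compound 1 to compound 3 (0.10 log units; within the scatter), so these two amides are not separated on this read-out. Nothing measured here explains either step. As far as these compounds go, it remains open whether piperidin-4-yl, which carries an amine, or plain cyclohexyl on the same carbon would read like oxan-4-yl or like 1H-pyrazol-3-yl.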